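The source may report more compounds than this note shows. Statements on the series, on what has been measured and on what is new or still open speak of the compounds shown alone.

Measured so far in an ADME assay on HEK293 cells (Homo sapiens) for cytotoxicity, with a stated time of 72 h; a lower number here means that less compound is needed, a higher number that more compound is needed for the effect:
- compound 1 `Cc1cc(NC(=O)Nc2ccc([N+](=O)[O-])c(C(F)(F)F)c2)c2ccccc2n1` gives > 25000 nM, a limit of the assay
- compound 2 `Cc1cc(NC(=O)Nc2ccc(C(=O)O)cc2)c2ccccc2n1` gives > 25000 nM, a limit of the assay
- compound 3 `Cc1cc(NC(=O)Nc2ccc3[nH]cnc3c2)c2ccccc2n1` gives > 25000 nM, a limit of the assay

Compound 2 stands only at a limit in this assay, without a number of its own. The same holds across the series: the limit of > 25000 nM in this assay, at which 3 of the 3 values shown sit, so no measured step between any two of these compounds can be read off, and nothing separates compound 2 from compound 1 or compound 3 on the numbers shown.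

Compound 4 `Cc1cc(NC(=O)Nc2ccc(Cl)cc2)c2ccccc2n1` is not yet measured. It differs from compound 2 in one place: chloro in place of carboxy on an aromatic carbon. For the measured compounds named here, with every value shown sitting at the limit, there is no measured step in this assay to lean on, so the expectation for the step from compound 2 to compound 4 is none beyond the scatter, and most likely a limit reported once more rather than a number.

On that basis the half-maximal effective concentration of compound 4 is expected at 30000 nM, within 10000 nM to 80000 nM, with the expected step that the limit leaves unreadable from compound 2 to compound 4.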

Compound 4, half-maximal effective concentration: > 25000 nM
Compound 4 was reported as a limit (the forecaster's own chance of this, stated with the estimate: 70%); the middle value is on the limit's open side.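

Compound 2 and compound 4 both stand at a limit, so no step can be read for chloro in place of carboxy on an aromatic carbon: the limit of > 25000 nM in this assay, at which 4 of the 4 values shown sit.

The compounds shown leave open whether any change on the shared core brings a numerical half-maximal effective concentration in this assay.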